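A few compounds are considered here, and "the series" means these few. Any claim that something is new, unique, unknown or untested is made for them only; others in the source may bear on it.

Compound 1 `Nc1ccc(S(=O)(=O)Nc2nc(-c3cccc([N+](=O)[O-])c3)cs2)cc1` gives the lower of the two numbers in hand: in an assay on isolated protein for inhibition of kynurenine 3-monooxygenase (Rattus norvegicus) (on this read-out lower numbers stand for stronger inhibition and higher numbers for weaker inhibition), compound 1 gives 40 nM. Compound 2 `O=C(O)c1cc(-c2cccc([N+](=O)[O-])c2)on1` lies far beyond the scatter from it, as in this assay compound 2 gives 2680 nM. Compound 3 `O=[N+]([O-])c1cccc(-c2csc(NS(=O)(=O)c3ccccc3)n2)c1` is reached from compound 1 by hydrogen in place of amino on an aromatic carbon. Among the compounds with values here, no measured pair shows this change; with the amino gone, a modest loss of inhibition is expected, the step of a 2.8-fold higher number from compound 1 to compound 3 (0.44 log units; beyond the scatter) estimated at a size only a little beyond the scatter, toward the higher numbers. Compound 3 is accordingly estimated at 110 nM, within 35 nM to 400 nM.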

Compound 3, half-maximal inhibitory concentration: 200 nM
Beside the measured number, compound 3's estimate is 1.8-fold (0.26 log units) below it, within the range that was stated.
By their numbers in this assay, from the lowest: compound 1; then compound 3; then compound 2.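

Hydrogen in place of amino on the aromatic carbon, 4-aminophenyl to phenyl, gives a 5.0-fold higher number from compound 1 to compound 3 (0.70 log units; beyond the scatter) in this assay, the first read of this position. Inhibition therefore does not depend entirely on the amino group: compound 3 still gives 200 nM, although the amino group of compound 1 adds a step beyond the scatter. Nothing in hand gives a reason for this step.

Going by these compounds, whether a methoxy group, a hydroxyl group or a carboxylic acid at this place would match the amino group remains open. So does the effect of a dimethylamino group there.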